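The compounds below may be only part of what the source reports. "The series", "measured", "known", "first", "only" and "open" are said of these compounds alone.

Of the compounds shown here, three built on a shared core have been tested in an assay on BTI-TN-5B1-4 cells for inhibition of Amine oxidase [flavin-containing] B (Homo sapiens), read by fluorescence and Amplex Red, using microsomes, with a stated time of 15 min; on this read-out lower numbers stand for stronger inhibition and higher numbers for weaker inhibition. Compound 1 `C#CCN1CCC(COC(=O)Nc2ccc(C(C)C)cc2)CC1` gives 316 nM in this assay. Compound 2 `C#CCN1CCCC(COC(=O)Nc2ccc(C(C)C)cc2)C1` has the same atoms joined differently, and the difference between the two cores is not broken down here. In this assay compound 2 gives 2860 nM, the higher of the two numbers, so the two values show compound 2 as the weaker inhibitor of the pair. Compound 3 `CC(C)c1ccc(NC(=O)OCC2CCN(Cc3ccccc3)CC2)cc1` differs from compound 1 by phenyl in place of ethynyl on a saturated chain carbon bound to an amine nitrogen in a ring. For compound 3 this assay reports only a limit, > 100000 nM, and not a number. The step of an at least 310-fold higher number from compound 1 to compound 3 (2.50 log units; beyond the scatter) accordingly rests on that limit (the limit of > 100000 nM in this assay, at which 1 of the 3 values shown sits).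

Compound 4 `CC(C)c1ccc(NC(=O)OCC2CCCN(Cc3ccccc3)C2)cc1` has not yet been measured in this assay. It differs from compound 2 by phenyl in place of ethynyl on a saturated chain carbon bound to an amine nitrogen in a ring, the same change that was made from compound 1 to compound 3, and that change occurs twice among these four compounds. Starting from compound 2, the expected step is a 70-fold higher number from compound 2 to compound 4 (1.84 log units; beyond the scatter), set beside the measured at least 310-fold higher number from compound 1 to compound 3 (2.50 log units; beyond the scatter); this expectation rests on the earlier step being so large and on compound 2 already giving 2860 nM before the change. Compound 4 is therefore expected to give roughly 200000 nM, and most likely only a limit. The expected range for compound 4 runs from 20000 nM to 2000000 nM.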

Compound 4, half-maximal inhibitory concentration: > 100000 nM
Compound 4 was reported as a limit; the forecaster's own chance of this, stated with the estimate: 80%; the middle value is on the limit's open side.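

In this assay compound 4 gives only a limit, > 100000 nM, and not a number, and it is not alone in this: the limit of > 100000 nM in this assay, at which 2 of the 4 values shown sit.

Putting phenyl in place of ethynyl, which reads as propargyl to benzyl when cut one bond further out, gives an at least 34-fold higher number from compound 2 to compound 4 (1.54 log units; beyond the scatter), so on both cores shown the change goes with much weaker inhibition, and no compound here goes against that. What this does not show is how large the change is on either core, or whether its size carries over from one core to the other, since both steps end at a limit: the same change on two cores in this assay, an at least 310-fold higher number (2.50 log units; beyond the scatter) from compound 1 to compound 3 and an at least 34-fold higher number (1.54 log units; beyond the scatter) from compound 2 to compound 4; the limit leaves it open whether they differ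

The compounds shown leave open whether any other group in place of ethynyl, such as a plain methyl, a hydrogen or a longer chain ending in a triple bond, would keep inhibition near that of compound 1 or fall away as phenyl does. As far as these compounds go, compound 3 and compound 4 also give no numbers, so it stays open whether the difference between the two cores seen with ethynyl persists with phenyl in its place.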